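A few compounds are considered here, and "the series" means these few. Any claim that something is new, unique, unknown or untested is made for them only; others in the source may bear on it.

Compound 1 `COC(=O)[C@H](CC(C)C)NC(=O)c1cccc(/C=C2\SC(=O)N(CC(=O)NOCc3ccccc3)C2=O)c1` was tested in a functional assay on RAW264.7 cells (Mus musculus) for inhibition, read by microscopy and resazurin assay, with a stated time of 72 h; on this read-out lower numbers stand for stronger inhibition and higher numbers for weaker inhibition. In this assay compound 1 gives only a limit, > 128000 nM. Compound 2 `C=CCONC(=O)CN1C(=O)S/C(=C\c2cccc(C(=O)N[C@H](C(=O)OC)C(C)C)c2)C1=O` likewise gives only a limit, > 128000 nM. Compound 2 thus stands at the limit that both shown values share, (the limit of > 128000 nM in this assay, at which 2 of the 2 values shown sit). Compound 3 `COC(=O)[C@@H](NC(=O)c1cccc(/C=C2\SC(=O)N(CC(=O)NOCc3ccccc3)C2=O)c1)C(C)C` differs from compound 2 by phenyl in place of vinyl on a saturated chain carbon bound to an oxygen on an unsaturated carbon. Compound 1 already carries the benzyloxy group that enters here, and in this assay compound 1 gives only the limit > 128000 nM. No step beyond the usual scatter is expected, a number no higher from compound 2 to compound 3 (the limit leaves the size open). Compound 3 is expected to give 128000 nM, within 64000 nM to 256000 nM, most likely again only as a limit.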

Compound 3, half-maximal inhibitory concentration: > 128000 nM
Compound 3: no number, only a limit; the forecaster's own chance of this, stated with the estimate: 85%; the middle value lies on the limit itself.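

No step can be read from compound 2 to compound 3 or from compound 1 to compound 3, since all three values are limits rather than numbers: the limit of > 128000 nM in this assay, at which 3 of the 3 values shown sit. The compounds shown leave open how strongly each inhibits, and whether swapping vinyl for phenyl or isobutyl for isopropyl changes that at all.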